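The source may report more compounds than this note shows. Statements on the series, on what has been measured and on what is new or still open speak of the compounds shown alone.

Measured compounds:
Compound 1, `CCSc1nc(N)c2nc(O)n(Cc3ccccc3)c2n1`: in a functional assay (spleen, spleen) for activation, with Mus musculus as the target (a lower number here means that less compound is needed, a higher number that more compound is needed for the effect), compound 1 gives 0.1 uM.
Compound 2, `CCCCCSc1nc(N)c2nc(O)n(Cc3ccccc3)c2n1`: in this assay compound 2 gives 10 uM.
Compound 3, `CNc1nc(N)c2nc(O)n(Cc3ccccc3)c2n1`: in this assay compound 3 gives 1 uM.

Compound 3 holds the second highest of the three numbers in this assay. Its nearest neighbour on the numbers is reached through a 10-fold higher number from compound 1 to compound 3 (1.00 log units; beyond the scatter), its furthest through a 10-fold lower number from compound 2 to compound 3 (1.00 log units; beyond the scatter).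

The next compound is compound 4, `CCCc1nc(N)c2nc(O)n(Cc3ccccc3)c2n1`, not yet measured in this assay. The change from compound 3: propyl in place of methylamino on an aromatic carbon.

Going by the values given here, no measured step exchanges methylamino for a plain chain, so the bearing is indirect. The two steps ending at compound 3 both exchange a sulfanyl chain for methylamino, and they run opposite ways: a 10-fold higher number from compound 1 to compound 3 (1.00 log units; beyond the scatter) against a 10-fold lower number from compound 2 to compound 3 (1.00 log units; beyond the scatter). The shorter chain on sulfur (compound 1) gave the lowest number, the longer one (compound 2) the highest. Propyl, with three carbons and no donor or acceptor, is closer in size to ethylsulfanyl than to pentylsulfanyl, so a modest move toward the number of compound 1 is expected rather than a move toward compound 2, with wide uncertainty given the scatter of each such step. The expected step is a 3.3-fold lower number from compound 3 to compound 4 (0.52 log units; beyond the scatter). Compound 4 is therefore estimated at 0.3 uM in this assay, with a range from 0.03 uM to 3 uM.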

Compound 4, minimum effective concentration: 1 uM
For compound 4 the middle estimate is 3.3-fold (0.52 log units) below the measured one; the range from low to high includes it.
By their numbers in this assay, from the lowest: compound 1; then compounds 3 and 4 (each within the scatter of the next); then compound 2.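

In this assay the exchange at this aromatic carbon, between two ring nitrogen atoms, shows that methylamino and propyl cannot be told apart (no change at the digits printed from compound 3 to compound 4 (within the scatter)), even though the hydrogen-bond donor and acceptor counted on methylamino are absent from propyl. The two sulfanyl groups stay apart from this pair in opposite directions, ethylsulfanyl on the low side (a 10-fold higher number from compound 1 to compound 4 (1.00 log units; beyond the scatter)) and pentylsulfanyl on the high side (a 10-fold lower number from compound 2 to compound 4 (1.00 log units; beyond the scatter)), so a plain propyl chain does not reproduce the number of compound 1 and the spread at this position is not a simple matter of heavy atoms in the group, as far as these four compounds go. No measurement at hand explains why the groups fall in this order.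

The compounds shown leave open whether the sulfur of compound 1 matters in its own right, since an ethoxy or a butyl group at this carbon, or a propylsulfanyl chain set against the ethylsulfanyl and pentylsulfanyl chains, would separate the atom from the chain length. They also leave open whether a dimethylamino group or a longer alkylamino chain would follow methylamino or the sulfanyl series.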